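The source may report more compounds than this note shows. Statements on the series, on what has been measured and on what is new or still open speak of the compounds shown alone.

Measured so far in a functional assay (aorta) with Rattus norvegicus as the target; a lower number here means a stronger inhibitor, a higher number a weaker inhibitor 
compound 1 `CCO/C(O)=C1\C(COCC/N=C(/N)S)=NC(C)=C(C(=O)OC)C1c1cccc(Cl)c1Cl` gives 1 nM 
compound 2 `CCO/C(O)=C1\C(COCCNc2cc(NC)ncn2)=NC(C)=C(C(=O)OC)C1c1cccc(Cl)c1Cl` gives 3.16 nM 

Compound 2 (3.16 nM) holds the higher of the two numbers in this assay and is the reference for compound 3 `CCO/C(O)=C1\C(COCCNc2nccnc2NC)=NC(C)=C(C(=O)OC)C1c1cccc(Cl)c1Cl`, not yet measured. The change is 3-(methylamino)pyrazin-2-yl in place of 6-(methylamino)pyrimidin-4-yl on an amine nitrogen and reads as 3-(methylamino)pyrazin-2-yl in place of 6-(methylamino)pyrimidin-4-yl on an amine nitrogen. Within the data shown here, no measured step covers this change directly. The nearest evidence is a 3.2-fold higher number from compound 1 to compound 2 (0.50 log units; beyond the scatter) and that modest step replaced a group without a ring by a larger one with a ring. Here the same atoms are kept, so a smaller step is expected, probably none beyond the scatter, and two compounds give no basis for a direction. The expected step is a 1.3-fold higher number from compound 2 to compound 3 (0.10 log units; within the scatter) and remains an estimate. In this assay the estimate for compound 3 is 4 nM with an expected range of 1 nM to 16 nM and the measurement is still to come.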

Compound 3, half-maximal inhibitory concentration: 5.01 nM
Compound 3: the middle estimate sits 1.3-fold (0.10 log units) below what was measured; measured number inside the range.
By their numbers in this assay, from the lowest: compound 1; then compounds 2 and 3 (each within the scatter of the next).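

In this assay, exchanging 6-(methylamino)pyrimidin-4-yl for 3-(methylamino)pyrazin-2-yl on the amine nitrogen gives a 1.6-fold higher number from compound 2 to compound 3 (0.20 log units; within the scatter), so this position does not tell the two groups apart, although their atoms are joined differently. Among these compounds, the ring-bearing group also gives a 5.0-fold higher number from compound 1 to compound 3 (0.70 log units; beyond the scatter) when it replaces the ringless group on the chain, so a second ring-bearing compound now stands on the same side of compound 1 as the first, with no compound here against that pattern. No measurement here offers a cause for either step.

Open, as far as these compounds go, is whether ring or size alone accounts for the gap to compound 1, which a plain amine or a longer chain ending in a ring could test. Also open, from the compounds shown here alone, is how far the methylamino group matters, since both ring-bearing compounds carry it.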